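The source may hold more compounds than are shown below. What is called first, only, known or untested is meant among the compounds shown, and "the series" means these compounds.

Measured compounds:
compound 1, `CCCCCc1cc2c(=O)n(CCCSc3nc(-c4cc(OC)c(OC)c(OC)c4)c(C#N)c(=O)[nH]3)cnc2s1`, 72.8 ug/mL
compound 2, `CCCCCCCc1cc2c(=O)n(CCSc3nc(-c4cc(OC)c(OC)c(OC)c4)c(C#N)c(=O)[nH]3)cnc2s1`, 72.6 ug/mL

In an ADME assay on PANC-1 cells (Homo sapiens) for inhibition, read by MTT assay (on this read-out higher numbers stand for weaker inhibition of growth and lower numbers for stronger inhibition of growth), compound 1 gives 72.8 ug/mL and compound 2 gives 72.6 ug/mL; the two numbers lie within the scatter of each other, so neither stands apart from the other. Compound 3, `CCCCCCCc1cc2c(=O)n(CCCSc3nc(-c4cc(OC)c(OC)c(OC)c4)c(C#N)c(=O)[nH]3)cnc2s1`, has not been measured. It differs from compound 1 by ethyl in place of hydrogen on a saturated chain carbon, five bonds along the chain from an aromatic carbon. Among the measured compounds shown here, no step between measured compounds covers this change, so there is nothing that shows the longer chain moving the read-out; the two measured numbers simply sit at one level. The step of a 1.0-fold lower number from compound 1 to compound 3 (0.00 log units; within the scatter) is therefore expected to stay within the scatter, with no preferred direction. Compound 3 is estimated at 72 ug/mL in this assay, with a range from 36 ug/mL to 145 ug/mL.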

Compound 3, concentration for 50% growth inhibition: > 100 ug/mL
Compound 3 was reported as a limit; the forecaster's own chance of this, stated with the estimate: 5%; middle value at least 1.3-fold (0.14 log units) away from the limit.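

In this assay, the first change read at this position, ethyl in place of hydrogen on a saturated chain carbon, five bonds along the chain from an aromatic carbon, gives an at least 1.3-fold higher number from compound 1 to compound 3 (0.13 log units; that floor lies within the scatter). The reading for compound 3 is a limit of the assay and not a number: the limit of > 100 ug/mL in this assay, at which 1 of the 3 values shown sits. The step is therefore a floor only, and since that floor lies within the scatter, the lengthening from pentyl to heptyl is not shown to matter, though a true step beyond the scatter is not excluded either.

The size of the step remains undetermined, as does how the read-out responds to a butyl chain or a chain longer than heptyl at this position. Also open, as far as these compounds go, is what a chain ending in an amine or a carboxylic acid would give on the shared core.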